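Amide variation: from compound 2 to compound 3

The source may hold more compounds than are shown below. What is called first, only, known or untested is meant among the compounds shown, and "the series" means these compounds.

Measured so far:
compound 1 `O=C(O)[C@@H]1CCCN1C(=O)/C=C/c1ccncc1-c1ccc2ccccc2c1` — 67%
compound 2 `NC(=O)/C=C/c1ccncc1-c1ccc2ccccc2c1` — 102%

In an assay on a protein complex for inhibition of CDK8/Cyclin C (Homo sapiens), with a stated time of 1 h, tested at 10 uM (a higher number here means more inhibition at the concentration tested (going by the name of the read-out), a lower number less inhibition), compound 2 gives 102%, the highest of the two numbers; compound 1 gives 67%. Among the compounds with values here, the only measured step is a number 35 percentage points higher from compound 1 to compound 2 (beyond the scatter), where a large ring-bearing group on the carbonyl carbon was exchanged for amino and the read-out rose.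

Compound 3 `CN(C)C(=O)/C=C/c1ccncc1-c1ccc2ccccc2c1` differs from compound 2 by dimethylamino in place of amino on a carbonyl carbon. The step from compound 1 to compound 2 bears on this only in part: it replaced a substituted amide nitrogen by the plain amino group, whereas here the amino group is substituted again, though with a smaller group than in compound 1. A step in the opposite direction, smaller than the measured one, is therefore expected in this assay. Compound 3 is estimated at 82% (range 55% to 102%), an expected step of a number 20 percentage points lower from compound 2 to compound 3 (beyond the scatter).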

Compound 3, a percentage reported as inhibition, at one concentration (the size of the read-out at that concentration, not a potency): 100%
Beside the measured number, compound 3's estimate is 18 percentage points below it, and the stated range covers the measured number.
By their numbers in this assay, from the lowest: compound 1; then compounds 3 and 2 (each within the scatter of the next).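

In this assay, the change from amino to dimethylamino on the carbonyl carbon gives a number 2 percentage points lower from compound 2 to compound 3 (within the scatter), so substitution on the amide nitrogen and the loss of the hydrogen-bond donor of amino leave the read-out unchanged within the scatter. The second comparison gives a number 33 percentage points higher from compound 1 to compound 3 (beyond the scatter), which shows that the lower number of compound 1 does not follow from a substituted amide nitrogen as such and instead goes with the 2-carboxypyrrolidin-1-yl group in particular. No measurement on hand explains either step.

Still open, from the compounds shown here alone, is whether the carboxylic acid or the ring of that group goes with the lower number, a question that an unsubstituted pyrrolidin-1-yl group would address. Also open, going by these compounds, is how far larger amines, such as diethylamino or a longer chain bearing an amine, are accommodated on this carbonyl carbon.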